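This account rests on a few compounds, and the source may have more. Where it says the series, first, only, none or still open, it means among the compounds named here.

Working notes on the series. Within the data shown here, compound 2 `Cc1cc(O)c(C2=NN(c3ccc(S(N)(=O)=O)cc3)C(/C=C/c3ccccc3)C2)cc1Cl` shows the highest of the two numbers so far in a functional assay on NCI-H522 cells (Homo sapiens) for antiproliferative activity, with a stated time of 48 h (a higher number here means a weaker inhibitor of growth, a lower number a stronger inhibitor of growth), where compound 2 gives 4620 nM. Its nearest neighbour is compound 1 `Cc1cc(O)c(C2=NN(c3ccc(S(N)(=O)=O)cc3)C(c3ccccc3O)C2)cc1Cl`, for which compound 1 gives 2150 nM in this assay; the step of a 2.1-fold higher number from compound 1 to compound 2 (0.33 log units; beyond the scatter) is modest but beyond the scatter. Compound 3 `COc1ccc(C2CC(c3cc(Cl)c(C)cc3O)=NN2c2ccc(S(N)(=O)=O)cc2)cc1OC` differs from compound 2 by 3,4-dimethoxyphenyl in place of 2-phenylethenyl on a saturated ring carbon. Among the measured compounds shown here, only the single step from compound 1 to compound 2 bears on this change, and it points to a ring on that carbon giving a somewhat lower number, so a step of a 1.5-fold lower number from compound 2 to compound 3 (0.19 log units; within the scatter) is expected. For compound 3 the estimate is 3000 nM, with a range from 1200 nM to 7500 nM.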

Compound 3, concentration for 50% growth inhibition: 2950 nM
Estimate against measurement, compound 3: 1.0-fold (0.01 log units) above; the range from low to high includes it.
By their numbers in this assay, from the lowest: compounds 1, 3 and 2 (each within the scatter of the next, the first and the last beyond it).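

In this assay on the saturated ring carbon, 3,4-dimethoxyphenyl in place of 2-phenylethenyl gives a 1.6-fold lower number from compound 2 to compound 3 (0.19 log units; within the scatter) and 3,4-dimethoxyphenyl in place of 2-hydroxyphenyl gives a 1.4-fold higher number from compound 1 to compound 3 (0.14 log units; within the scatter) so compound 3 separates from neither neighbour. A ring bearing two methoxy groups therefore sits within the scatter of both earlier groups at this carbon, and only compound 1 and compound 2 stand beyond the scatter of each other.

From the compounds shown here alone, whether an amine or a carboxylic acid on this carbon would shift the number beyond the scatter stays open. Nothing at hand accounts for these numbers.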